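The source may report more compounds than this note shows. Statements on the series, on what has been measured and on what is new or still open speak of the compounds shown alone.

Compound 1, `Fc1ccc(-c2nc3c(C4CCNCC4)nccc3[nH]2)cc1F`, gives 200000 nM in a physicochemical assay for solubility, read by HPLC, using the shake flask method, in phosphate buffer, with a stated time of 20 h, at pH 6.5; a lower number here means a less soluble compound, a higher number a more soluble compound.
Compound 2, `Fc1ccc(-c2nc3c(N4CCNCC4)nccc3[nH]2)cc1F`, gives 150000 nM in this assay.

These two share one core and differ only in the saturated ring attached to it. Compound 2 sits alongside compound 1: the step of a 1.3-fold lower number from compound 1 to compound 2 (0.12 log units; within the scatter) lies within the scatter of this assay, so the two numbers cannot be told apart.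

Compound 3, `Fc1ccc(-c2nc3c(N4CCCNCC4)nccc3[nH]2)cc1F`, is the next compound to be tested. Compared with compound 2 the change is 1,4-diazepan-1-yl in place of piperazin-1-yl on an aromatic carbon. The ring grows by one carbon but keeps its two nitrogens, one hydrogen-bond donor and two acceptors.

Going by the values given here, only one measured step bears on this at all, and only loosely: the swap of piperidin-4-yl for piperazin-1-yl between compound 1 and compound 2 also altered the saturated ring at this position, and it produced a 1.3-fold lower number from compound 1 to compound 2 (0.12 log units; within the scatter), a change within the scatter. Widening the ring by one carbon is a smaller alteration than that exchange, so for compound 3 the step of no change at the digits printed from compound 2 to compound 3 (within the scatter) is expected to stay within the scatter. Compound 3 is therefore estimated at 150000 nM, with a range from 70000 nM to 320000 nM.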

Compound 3, solubility: 165000 nM
Estimate against measurement, compound 3: 1.1-fold (0.04 log units) below, and the stated range covers the measured number.
By their numbers in this assay, from the lowest: compounds 2, 3 and 1 (each within the scatter of the next).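

In this assay, going from the six-membered ring of piperazin-1-yl to the seven-membered ring of 1,4-diazepan-1-yl gives a 1.1-fold higher number from compound 2 to compound 3 (0.04 log units; within the scatter) and so leaves the two compounds indistinguishable, which means this position tolerates one extra ring carbon with no readable effect on the number. Set against the piperidin-4-yl group, which is attached through carbon rather than nitrogen, the new ring gives a 1.2-fold lower number from compound 1 to compound 3 (0.08 log units; within the scatter) and again cannot be told apart, so all three saturated rings shown here form a single group of equal numbers with no compound going against it. No measurement is available that could explain why these numbers stay together.

The compounds shown leave open whether this sameness holds for a ring with only one nitrogen in the position of the second, such as morpholine, or for a smaller ring such as pyrrolidine. They also leave open what happens when the free ring nitrogen carries a methyl or acetyl group, or when the ring is replaced by an open chain ending in an amine.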